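Working notes: a halophenyl swap on compound 3

The source may hold more compounds than are shown below. What is called first, only, known or untested is meant among the compounds shown, and "the series" means these compounds.

Measured in a functional assay on Caco-2 cells (Homo sapiens) for inhibition, read by MTT assay, with a stated time of 48 h, tested at 10 uM (a lower number here means less inhibition of growth, a higher number more inhibition of growth at the concentration tested), so far:
- compound 1 `Cc1cc(=O)c2c(O)cc(O)c([C@H]3CCN(C)C[C@H]3OC(=O)c3ccco3)c2o1` gives 33%
- compound 2 `Cc1cc(=O)c2c(O)c(CN3CCC(c4ccccc4)CC3)c(O)c([C@H]3CCN(C)C[C@H]3O)c2o1` gives 21%
- compound 3 `Cc1oc2c([C@H]3CCN(C)C[C@H]3O)c(O)cc(O)c2c(=O)c1C(O)c1ccc(Cl)cc1` gives 3%

Compound 3 stands lowest of these three (3%). Compound 2 and compound 1 both lie above it, and both gaps are beyond the scatter. These three compounds differ in more than one place, so their values say nothing about a single change.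

The next compound is compound 4 `Cc1oc2c([C@H]3CCN(C)C[C@H]3O)c(O)cc(O)c2c(=O)c1C(O)c1ccc(F)c(Br)c1`, which has 3-bromo-4-fluorophenyl in place of 4-chlorophenyl on a saturated chain carbon bound to an aromatic carbon and an oxygen on a saturated carbon. The two groups differ only in what the ring carries. Among the compounds with values here, no measured pair in this set shows what such an exchange does in this assay, so the expectation is a cautious one.

A small step is expected, with no change beyond the scatter the most likely outcome. Compound 3 at 3% leaves little room downward, so any movement is more likely to be upward. The expected step is a number 7 percentage points higher from compound 3 to compound 4 (within the scatter) and it stays within the scatter.

In this assay compound 4 is estimated at 10% in a range from 0% to 28% (an expectation, not a measurement).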

Compound 4, percent growth inhibition at one concentration: 6%
For compound 4 the middle estimate is 4 percentage points above the measured one, within the range that was stated.
By their numbers in this assay, from the lowest: compounds 3 and 4 (each within the scatter of the next); then compound 2; then compound 1.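

Working notes, reading of the step: in this assay, the change from (4-chlorophenyl)(hydroxy)methyl to (3-bromo-4-fluorophenyl)(hydroxy)methyl gives a number 3 percentage points higher from compound 3 to compound 4 (within the scatter), the first comparison in this series that differs in one place only. At this place, then, this exchange of what the ring carries, with 8 heavy atoms entering and 7 leaving, does not move the reading beyond the usual scatter, although compound 3 at 3% and compound 4 at 6% both sit close to the bottom of the scale, so the pair tests only a narrow part of it. Nothing available explains the size of this step.

Whether a phenyl ring carrying an amine or a carboxylic acid, or a longer chain in place of the phenyl ring, would shift the number at this place remains open, since only two halophenyl groups are shown there. Steps from compound 1 or compound 2 to the other compounds cannot be read, as those compounds differ in more than one place.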